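Pyridyl for Phenyl on a Chalcone Chain

This account rests on a few compounds, and the source may have more. Where it says the series, first, only, none or still open, it means among the compounds named here.

Compound 1 `COc1cccc(/C=C/C(=O)c2ccc(OC)c3c2OC(C)(C)C=C3)c1`: > 10000 nM
Compound 2 `COc1ccc(C(=O)/C=C/c2ccc3ccccc3c2)c2c1C=CC(C)(C)O2`: 2140 nM

Compound 1 stands at the limit of the assay: in a functional assay on SW-620 cells (Homo sapiens) for antiproliferative activity, read by MTT assay, with a stated time of 24 h (a higher number here means a weaker inhibitor, a lower number a stronger inhibitor), compound 1 returns > 10000 nM, which is a limit and not a number (the limit of > 10000 nM in this assay, at which 1 of the 2 values shown sits). Compound 2 gives 2140 nM in this assay. Compound 3 `COc1ccc(/C=C/C(=O)c2ccc(OC)c3c2OC(C)(C)C=C3)cn1` carries 6-methoxypyridin-3-yl in place of 3-methoxyphenyl on a double-bonded chain carbon bound to a double-bonded chain carbon. Within the data shown here, no measured step between two compounds is available here, so the size of this change is untested. Compound 3 is estimated at 15000 nM in this assay, within 5000 nM to 50000 nM. The expected step that the limit leaves unreadable from compound 1 to compound 3 is small, likely no more than the usual scatter.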

Compound 3, half-maximal inhibitory concentration: > 10000 nM
Compound 3: no number, only a limit; the forecaster's own chance of this, stated with the estimate: 60%; the middle value does not contradict the limit.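

In this assay compound 3 returns > 10000 nM, which is a limit and not a number. Compound 1 also stands at a limit, so no step from it to compound 3 can be read: the limit of > 10000 nM in this assay, at which 2 of the 3 values shown sit.

As far as these compounds go, whether 6-methoxypyridin-3-yl in place of 3-methoxyphenyl alters the activity at all remains open.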